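This account rests on a few compounds, and the source may have more. Where it says the series, first, only, none or still open, it means among the compounds named here.

Of the compounds shown here, two of a shared core have been tested in a functional assay on MKN-45 cells (Homo sapiens) for inhibition, read by MTT assay, with a stated time of 72 h; on this read-out lower numbers stand for stronger inhibition and higher numbers for weaker inhibition. Compound 1, with structure `COc1cc2c(Oc3ccc(NC(=O)c4nn(-c5ccccc5)c(=O)cc4C)cc3F)ccnc2cc1OCCCN1CCN(C)CC1`, gives 130 nM in this assay. Compound 2, with structure `COc1cc2c(Oc3ccc(NC(=O)c4nn(-c5ccccc5C(F)(F)F)c(=O)cc4C)cc3F)ccnc2cc1OCCCN1CCCCC1`, gives 90 nM in this assay. Compound 2 carries the smaller of the two numbers, but the gap between compound 2 and compound 1 sits within the usual scatter of repeated measurements, so the two cannot be told apart on this evidence.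

Compound 3, with structure `COc1cc2c(Oc3ccc(NC(=O)c4nn(-c5ccccc5C(F)(F)F)c(=O)cc4C)cc3F)ccnc2cc1OCCCN1CCN(C)CC1`, has not yet been measured. It differs from compound 2 in a single place: 4-methylpiperazin-1-yl in place of piperidin-1-yl on a saturated chain carbon, three bonds along the chain from an oxygen on an aromatic ring. The group that enters in compound 3 is the same group that compound 1 already carries at that position, so compound 3 combines the chain-end group of compound 1 with the trifluoromethyl-bearing ring of compound 2. Since compound 1 and compound 2 sit within the scatter of each other, no step beyond the scatter is expected from compound 2 to compound 3 in this assay, and the estimated step is a 1.1-fold higher number from compound 2 to compound 3 (0.05 log units; within the scatter). Compound 3 is therefore expected to give about 100 nM, with a likely range from 40 nM to 250 nM.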

Compound 3, half-maximal inhibitory concentration: 40 nM
Estimate against measurement, compound 3: 2.5-fold (0.40 log units) above, within the range that was stated.
By their numbers in this assay, from the lowest: compound 3; then compounds 2 and 1 (each within the scatter of the next).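

In this assay, compound 1 and compound 2 differ in two places at once, so neither change could be read alone; with the rest of the structure now held fixed, 4-methylpiperazin-1-yl in place of piperidin-1-yl on the saturated chain carbon gives a 2.3-fold lower number from compound 2 to compound 3 (0.35 log units; beyond the scatter). The other change can now be read too: with 4-methylpiperazin-1-yl present in both compounds, trifluoromethyl in place of hydrogen on an aromatic carbon gives a 3.3-fold lower number from compound 1 to compound 3 (0.51 log units; beyond the scatter), so each change on its own moves the number beyond the scatter, though each is seen in one pair only. Nothing available here explains either step.

The compounds shown leave open whether the step from piperidin-1-yl to 4-methylpiperazin-1-yl would keep its size on a compound without the trifluoromethyl group. They also leave open how other groups would behave, such as morpholine or dimethylamine at the end of the chain, a shorter or longer chain, or a chlorine atom in place of the trifluoromethyl group.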